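Fluoro added to the phenyl group of compound 3

This account rests on a few compounds, and the source may have more. Where it says the series, first, only, none or still open, it means among the compounds named here.

Measured so far in a functional assay on CHO cells for positive allosteric modulation of metabotropic glutamate receptor 2 (Homo sapiens), with a stated time of 30 min; a lower number here means that less compound is needed, a higher number that more compound is needed for the effect:
- compound 1 `CC(C)CCn1ccc(OCc2ccccc2)c(C#N)c1=O` gives 2950 nM
- compound 2 `CC(C)CCn1ccc(N2CCCC(c3ccccc3)C2)c(C#N)c1=O` gives 3310 nM
- compound 3 `N#Cc1c(N2CCC(c3ccccc3F)CC2)ccn(CC2CC2)c1=O` gives 81 nM

Compound 3 has the lowest number of the three, and its gaps to compound 1 and to compound 2 both lie beyond the usual scatter, so it is the most potent compound measured here. Compound 1 and compound 2 carry a different chain on the ring nitrogen and different groups on the core, so neither pair gives a single-point step that could be read as a guide.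

Compound 4 `N#Cc1c(N2CCC(c3ccc(F)cc3F)CC2)ccn(CC2CC2)c1=O` is the next compound to be measured. It differs from compound 3 in one place: fluoro in place of hydrogen on an aromatic carbon. No step of this kind has yet been measured in this series, so there is no shown change on which to lean. The change is a single heavy atom on the phenyl ring of a compound whose number is already low; the expectation is a small step in this assay, in either direction, most likely not beyond the scatter.

Compound 4 is therefore expected to give about 70 nM in this assay, within a range of 25 nM to 200 nM, which as a step from compound 3 to compound 4 means a 1.2-fold lower number from compound 3 to compound 4 (0.06 log units; within the scatter).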

Compound 4, half-maximal effective concentration: 68 nM
Estimate against measurement, compound 4: 1.0-fold (0.01 log units) above; low and high end bracket the measured number.
By their numbers in this assay, from the lowest: compounds 4 and 3 (each within the scatter of the next); then compounds 1 and 2 (each within the scatter of the next).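

In this assay, among these compounds, the change from 2-fluorophenyl to 2,4-difluorophenyl gives a 1.2-fold lower number from compound 3 to compound 4 (0.08 log units; within the scatter), the first single-place step that can be read. A fluoro group on this aromatic carbon, meta to a fluoro group and para to a large group, is therefore accepted without a change beyond the scatter, and the low number of compound 3 is retained in compound 4. No measured data given here explain this step.

From the compounds shown here alone, this reading rests on one small group at one position, so it remains open whether chloro, methoxy, trifluoromethyl or an amine at the same carbon would also stay within the scatter. Also open, going by these compounds, is whether the same step would read alike on the phenyl group without the 2-fluoro substituent, or with a longer chain in place of the cyclopropylmethyl group on the ring nitrogen.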